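Chalcone-pyrazole series: aryl ketone swap on the trimethoxy core

A few compounds are considered here, and "the series" means these few. Any claim that something is new, unique, unknown or untested is made for them only; others in the source may bear on it.

Measured so far:
- compound 1, `COc1ccc(-c2cc(/C=C/C(=O)c3ccc(N)cc3)[nH]n2)cc1`: in a functional assay on UACC-62 cells (Homo sapiens) for inhibition, read by sulforhodamine B assay, with a stated time of 48 h (a higher number here means that more compound is tolerated, a lower number that less compound is tolerated), compound 1 gives 5840 nM
- compound 2, `COc1cc(-c2cc(/C=C/C(=O)c3ccc(N)cc3)[nH]n2)cc(OC)c1OC`: in this assay compound 2 gives 7510 nM

The two numbers for compound 1 and compound 2 lie within the scatter of each other, so compound 2 does not stand apart from compound 1 on the numbers shown; the two compounds share the chalcone-pyrazole core and the 4-aminophenyl on the carbonyl carbon, and differ only in the substitution of the aryl ring on the pyrazole.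

Compound 3, `COc1cc(-c2cc(/C=C/C(=O)c3ccc(Cl)c(Cl)c3)[nH]n2)cc(OC)c1OC`, keeps the core of compound 2 and changes the ketone aryl: 3,4-dichlorophenyl in place of 4-aminophenyl on a carbonyl carbon. For the measured compounds named here, no pair of measured compounds shows this kind of change, so there is no step to lean on. With nothing in the series to anchor a direction, the step from compound 2 to compound 3 in this assay is expected to be small, most likely within the scatter, and the estimate is widened to allow for either direction.

For compound 3 in this assay the expected value is 6500 nM, in a range from 2500 nM to 17000 nM, which means an expected step of a 1.2-fold lower number from compound 2 to compound 3 (0.06 log units; within the scatter).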

Compound 3, concentration lethal to 50% of the cells: > 100000 nM
Compound 3 ended at the assay's limit; the forecaster's own chance of this, stated with the estimate: 5%; middle value at least 15-fold (1.18 log units) away from the limit.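

For the compounds shown here, the ketone aryl on the carbonyl carbon is the first place where a change clearly moves the read-out: compound 1 and compound 2 lie within the scatter of each other, whereas 3,4-dichlorophenyl in place of 4-aminophenyl gives an at least 13-fold higher number from compound 2 to compound 3 (1.12 log units; beyond the scatter) in this assay. On the trimethoxy core, this position therefore has a far larger bearing on how much compound is tolerated than the earlier pair could reveal. The reading for compound 3 is a limit of the assay and not a number, so the step marks only a minimum size: the limit of > 100000 nM in this assay, at which 1 of the 3 values shown sits.

A single swap at this position cannot separate the departure of the 4-aminophenyl from the entry of the two chlorines, and it leaves open whether the same swap would carry the same weight on the core of compound 1. An unsubstituted phenyl, a 4-chlorophenyl or a 4-hydroxyphenyl on the carbonyl carbon would show whether the amine or the chlorine atoms account for the step.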